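Aryl exchange on the acyl urea of a shared thiazole core

The source may hold more compounds than are shown below. What is called first, only, known or untested is meant among the compounds shown, and "the series" means these compounds.

Compound 1 `CN(C(=O)NC(=O)c1c(F)cccc1F)c1nc(C(F)(F)F)c(C(=O)N/N=C/c2cc(C(F)(F)F)cc(C(F)(F)F)c2)s1`: 6.85 ug/mL
Compound 2 `CN(C(=O)NC(=O)c1cccc(C(F)(F)F)c1)c1nc(C(F)(F)F)c(C(=O)N/N=C/c2cc(C(F)(F)F)cc(C(F)(F)F)c2)s1`: 6.08 ug/mL

Both were tested in a functional assay on MCF7 cells (Homo sapiens) for inhibition, read by MTT assay, with a stated time of 72 h; on this read-out lower numbers stand for stronger inhibition and higher numbers for weaker inhibition. Compound 2 stands at the lower end of the two numbers, but the gap to compound 1, a 1.1-fold lower number from compound 1 to compound 2 (0.05 log units; within the scatter), is within the scatter, so no order between them can be read. Compound 3 `CN(C(=O)NC(=O)c1ccc(Cl)cc1Cl)c1nc(C(F)(F)F)c(C(=O)N/N=C/c2cc(C(F)(F)F)cc(C(F)(F)F)c2)s1` differs from compound 2 by 2,4-dichlorophenyl in place of 3-(trifluoromethyl)phenyl on a carbonyl carbon. Among the measured compounds shown here, the one step that bears on this change is a 1.1-fold lower number from compound 1 to compound 2 (0.05 log units; within the scatter), an exchange of the aryl group at the same carbonyl carbon, and it stayed within the scatter. Compound 3 is therefore expected to give 6.5 ug/mL, between 3.2 ug/mL and 13 ug/mL. The expected step of a 1.1-fold higher number from compound 2 to compound 3 (0.03 log units; within the scatter) should not exceed the scatter.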

Compound 3, half-maximal inhibitory concentration: > 100 ug/mL
Compound 3: no number, only a limit; the forecaster's own chance of this, stated with the estimate: 5%; at least 15-fold (1.18 log units) between middle value and limit.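

Among the compounds shown here, exchanging the aryl group on this carbonyl carbon had so far changed nothing readable in this assay, but the outcome proves to depend strongly on which aryl group is present. 2,4-Dichlorophenyl gives an at least 16-fold higher number from compound 2 to compound 3 (1.21 log units; beyond the scatter), and an at least 14-fold higher number from compound 1 to compound 3 (1.16 log units; beyond the scatter). The entry for compound 3 is a limit and not a number: the limit of > 100 ug/mL in this assay, at which 1 of the 3 values shown sits.

The compounds shown leave open whether one chlorine, as in 4-chlorophenyl, would give the same result as the two in 2,4-dichlorophenyl. They also leave open how an aryl group carrying an amine or a carboxylic acid would behave at this carbonyl carbon.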